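Bromo to cyano on the benzamide of a chromone amide

A few compounds are considered here, and "the series" means these few. Any claim that something is new, unique, unknown or untested is made for them only; others in the source may bear on it.

Measured compounds:
compound 1 `COc1cc2oc(-c3cccc(NC(=O)c4ccc(C(F)(F)F)cc4)c3)cc(=O)c2c(OC)c1OC`: "active" (no number reported) in the assay described below
compound 2 `COc1cc2oc(-c3cccc(NC(=O)c4ccc(Br)cc4)c3)cc(=O)c2c(OC)c1OC`: 63.6%

In a functional assay on UO-31 cells (Homo sapiens) for inhibition, read by sulforhodamine B assay, tested at 10 uM (on this read-out lower numbers stand for less inhibition and higher numbers for more inhibition at the one concentration tested (going by the name of the read-out)), compound 1 is reported only as "active" (no number reported), without a number. In this assay compound 2 gives 63.6%, and this is the only number shown in the series, so compound 2 is the sole reference point. Compound 3 `COc1cc2oc(-c3cccc(NC(=O)c4ccc(C#N)cc4)c3)cc(=O)c2c(OC)c1OC` has not been measured in this assay. It differs from compound 2 in one place: cyano in place of bromo on an aromatic carbon. Going by the values given here, no step between two measured compounds is available, so the size of this change can only be guessed. A step from compound 2 to compound 3 of modest size, possibly downward, is expected, with the scatter of this assay easily covering it. Compound 3 is therefore estimated at 55%, with a range from 30% to 80%, an expected step of a number 8.6 percentage points lower from compound 2 to compound 3 (within the scatter).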

Compound 3, a percentage reported as inhibition, at one concentration (the size of the read-out at that concentration, not a potency): "active" (no number reported)
Nothing numeric was reported for compound 3; the estimate stays without a comparison.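

In this assay, going by these compounds alone, compound 3 gives "active" (no number reported), so no step from compound 2 to it can be read. No further data shown bear on this result. The compounds shown leave open how the inhibition of compound 3 compares numerically with that of compound 2.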